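The source may hold more compounds than are shown below. What is called first, only, known or untested is meant among the compounds shown, and "the series" means these compounds.

Measured compounds:
compound 1 `CCCNC(=O)c1ccc(Oc2nc(-c3c(C)noc3C)cnc2N)cc1` — 47800 nM
compound 2 `Cc1noc(C)c1-c1cnc(N)c(Oc2ccc(C(=O)NC3CCCCC3)cc2)n1` — 40400 nM
compound 3 `Cc1noc(C)c1-c1cnc(N)c(Oc2ccc(C(=O)Nc3ccccc3Cl)cc2)n1` — 60500 nM

All three share a core and differ only in the group on the amide-type nitrogen. In a functional assay on U-87MG ATCC cells for inhibition, with U-87 MG (Homo sapiens) as the target, read by MTT assay, with a stated time of 72 h (on this read-out lower numbers stand for stronger inhibition and higher numbers for weaker inhibition), compound 1 gives 47800 nM, the second highest of the three numbers. Its nearest neighbour is compound 2, as the step of a 1.2-fold lower number from compound 1 to compound 2 (0.07 log units; within the scatter) shows; its furthest is compound 3, with a 1.3-fold higher number from compound 1 to compound 3 (0.10 log units; within the scatter). Neither step reaches beyond the scatter, so the three compounds cannot be told apart on this read-out.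

Compound 4 `Cc1noc(C)c1-c1cnc(N)c(Oc2ccc(C(=O)Nc3cccc(Cl)c3)cc2)n1` has not yet been measured. It differs from compound 1 by 3-chlorophenyl in place of propyl on an amide-type nitrogen. Among the compounds with values here, two measured steps bear on this change: a 1.3-fold higher number from compound 1 to compound 3 (0.10 log units; within the scatter) and a 1.5-fold higher number from compound 2 to compound 3 (0.18 log units; within the scatter), both within the scatter. A 3-chlorophenyl group is therefore expected to behave like the other groups on this nitrogen, and no step beyond the scatter is expected in this assay, in either direction; the estimated step is a 1.2-fold higher number from compound 1 to compound 4 (0.06 log units; within the scatter). Compound 4 is estimated at 55000 nM, with a range from 25000 nM to 120000 nM.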

Compound 4, half-maximal inhibitory concentration: 11500 nM
Beside the measured number, compound 4's estimate is 4.8-fold (0.68 log units) above it, outside the stated range (below it).
By their numbers in this assay, from the lowest: compound 4; then compounds 2, 1 and 3 (each within the scatter of the next).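

The three earlier compounds suggested that the group on this amide-type nitrogen made no difference in this assay, but 3-chlorophenyl breaks that picture: in place of propyl it gives a 4.2-fold lower number from compound 1 to compound 4 (0.62 log units; beyond the scatter) and in place of cyclohexyl it gives a 3.5-fold lower number from compound 2 to compound 4 (0.55 log units; beyond the scatter) on the same shared core. A chlorinated benzene ring on this nitrogen is not enough in itself, since 3-chlorophenyl in place of 2-chlorophenyl gives a 5.3-fold lower number from compound 3 to compound 4 (0.72 log units; beyond the scatter). Compound 3 stays within the scatter of compounds 1 and 2. Among these compounds, then, the result depends on which of the two chlorophenyl groups is present.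

From the compounds shown here alone, whether bromine or a methyl group in place of the chlorine of compound 4, or an unsubstituted phenyl on this nitrogen, would keep this step remains open. Nothing given here explains why the two chlorophenyl groups part.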